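A fluoro added to the central ring of compound 2

A few compounds are considered here, and "the series" means these few. Any claim that something is new, unique, unknown or untested is made for them only; others in the source may bear on it.

Measured compounds in a functional assay on A549 cells (Homo sapiens) for cytotoxicity, read by MTT assay, with a stated time of 72 h; a lower number here means a stronger inhibitor, a higher number a weaker inhibitor:
compound 1 `O=C(Nc1ccc(Oc2ccnc3[nH]ccc23)cc1)c1cc(-c2ccc(C(F)(F)F)cc2)ncn1` — compound 1 gives 9380 nM
compound 2 `O=C(Nc1ccc(Oc2ccnc3[nH]ccc23)cc1)c1cc(-c2ccccc2)ncn1` — compound 2 gives 140 nM
compound 3 `O=C(Nc1ccc(Oc2ccnc3[nH]ccc23)cc1)c1cc(-c2ccc(Br)cc2)ncn1` — compound 3 gives 9870 nM

Compound 2 stands lowest of the three numbers in this assay. The step of a 67-fold lower number from compound 1 to compound 2 (1.83 log units; beyond the scatter) and the step of a 71-fold higher number from compound 2 to compound 3 (1.85 log units; beyond the scatter) both lie beyond the scatter, so compound 2 is the strongest inhibitor of the set, while the step of a 1.1-fold higher number from compound 1 to compound 3 (0.02 log units; within the scatter) is within the scatter.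

Compound 4 `O=C(Nc1ccc(Oc2ccnc3[nH]ccc23)c(F)c1)c1cc(-c2ccccc2)ncn1` differs from compound 2 by fluoro in place of hydrogen on an aromatic carbon, ortho to a large group and meta to a large group. For the measured compounds named here, every measured step concerns the other aromatic ring, the one carrying trifluoromethyl, bromo or hydrogen; no measured step alters the ring that compound 4 changes. The data hold no comparison of this kind, so the expectation is for no step beyond the scatter. Compound 4 is therefore estimated at 150 nM, with a range from 50 nM to 500 nM. The expected step is a 1.1-fold higher number from compound 2 to compound 4 (0.03 log units; within the scatter).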

Compound 4, half-maximal inhibitory concentration: 180 nM
Beside the measured number, compound 4's estimate is 1.2-fold (0.08 log units) below it, within the range that was stated.
By their numbers in this assay, from the lowest: compounds 2 and 4 (each within the scatter of the next); then compounds 1 and 3 (each within the scatter of the next).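

In this assay, the ring that takes the fluoro proves tolerant at this place, ortho to a large group and meta to a large group, with a 1.3-fold higher number from compound 2 to compound 4 (0.11 log units; within the scatter). The earlier compounds showed only the other aromatic ring, where a single bromo in place of hydrogen gives a 71-fold higher number from compound 2 to compound 3 (1.85 log units; beyond the scatter), so among these compounds the sharp loss seen on adding one atom to compound 2 belongs to that ring and does not appear at the fluoro position. No measurement available here explains this difference between the two rings.

The compounds shown leave open whether this position would accept chloro, methoxy or an amine as it accepts fluoro. They also leave open whether the fluoro would behave the same way with bromo or trifluoromethyl on the other ring, as in compound 3 and compound 1.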